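The source may report more compounds than this note shows. Statements on the series, on what has been measured and on what is new or still open speak of the compounds shown alone.

Of the compounds shown here, three have numbers so far in a functional assay on HL-60 cells (Homo sapiens) for cytotoxicity, read by luminescence and CellTiter-Glo, with a stated time of 3 days; a lower number here means a stronger inhibitor, a higher number a weaker inhibitor. Compound 1 (`N#Cc1ccc(NC(=O)c2ccc(Br)cc2O)c(Cl)c1`) gives 730 nM. Compound 2 (`O=C(Nc1cc(C(F)(F)F)cc(C(F)(F)F)c1)c1ccc(Br)cc1O`) gives 270 nM, the lowest of the three numbers. Compound 3 (`N#Cc1cccc(NC(=O)c2cc(F)ccc2O)c1`) gives 7750 nM. The gaps from compound 2 to the other two both lie beyond the scatter, so compound 2 is the most potent of the three, with compound 1 its nearest neighbour and compound 3 the furthest away. Going by the values given here, these three differ from one another in more than one place, so no measured pair isolates a single change, and the size of a halogen exchange cannot be read from them.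

Next in line is compound 4 (`O=C(Nc1cc(C(F)(F)F)cc(C(F)(F)F)c1)c1ccc(Cl)cc1O`), which differs from compound 2 in one place: chloro in place of bromo on an aromatic carbon. This is chloro in place of bromo on an aromatic carbon, meta to a hydroxy group and para to a large group, which reads one bond further out as 4-bromo-2-hydroxyphenyl to 4-chloro-2-hydroxyphenyl. Among the compounds with values here, with no measured precedent, the expectation rests on the structural change alone: no shift beyond the scatter in this assay, with any drift towards a slightly higher number. The expected result is a step of a 1.2-fold higher number from compound 2 to compound 4 (0.07 log units; within the scatter). For compound 4 the estimated value is 320 nM, with an expected range of 130 nM to 750 nM.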

Compound 4, half-maximal inhibitory concentration: 200 nM
For compound 4 the middle estimate is 1.6-fold (0.20 log units) above the measured one; the range from low to high includes it.
By their numbers in this assay, from the lowest: compounds 4 and 2 (each within the scatter of the next); then compound 1; then compound 3.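

Going by these compounds alone, this is the first step that isolates a single change: in this assay, chloro in place of bromo gives a 1.4-fold lower number from compound 2 to compound 4 (0.13 log units; within the scatter), which lies within the scatter. On the aromatic carbon meta to a hydroxy group and para to a large group, the two halogens therefore cannot be told apart in this assay, at least with the rest of compound 2 held constant, so the potency of this pair does not depend on bromo specifically. No measurement at hand explains this equivalence, and the result gives no basis for assigning any property to either halogen.

The compounds shown leave open whether the same exchange would be equally silent on the core of compound 1, where the group on the amide nitrogen differs. They also leave open whether this position needs a halogen at all, as only bromo and chloro appear here, so a hydrogen, an amine, a methoxy group or a carboxylic acid at the same carbon would test how much the position can tolerate.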